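A few compounds are considered here, and "the series" means these few. Any claim that something is new, unique, unknown or untested is made for them only; others in the source may bear on it.

Within the data shown here, compound 2 `CCCCc1nc(=O)c(S(=O)(=O)c2ccc(-n3cc(Cl)ccc3=O)cc2)c(O)n1-c1c(OC)cccc1OC` stands highest of the two numbers so far in an ADME assay on microsomes from liver (Mus musculus) for metabolic stability, using NADPH, with a stated time of 10 min; on this read-out higher numbers stand for a more stable compound and lower numbers for a less stable compound: compound 2 gives 100%. Among the measured compounds shown here, its only neighbour is compound 1 `CCCCc1nc(=O)c(S(=O)(=O)c2ccc(-c3ccc(F)cc3)cc2)c(O)n1-c1c(OC)cccc1OC`, which in this assay gives 47%. For the measured compounds named here, the single measured step, a number 53 percentage points higher from compound 1 to compound 2 (beyond the scatter), is large and beyond the scatter; it brought in the six-membered aromatic ring with one hetero atom in place of the fluorine-bearing aromatic ring of carbon only.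

Compound 3 `CCCCc1nc(=O)c(S(=O)(=O)c2ccc(C)cc2)c(O)n1-c1c(OC)cccc1OC` is the next member, not yet measured in this assay. It differs from compound 2 in one place: one carbon atom in place of a group of 8 heavy atoms (5 carbon, 1 nitrogen, 1 oxygen, 1 chlorine; one six-membered aromatic ring with 1 hetero atom), on an aromatic carbon. The entering methyl sits on an aromatic carbon of a six-membered aromatic ring of carbon only, para to a large group.

Going by the values given here, only the step from compound 1 to compound 2 bears on this change, and the step to compound 3 takes out again the very ring that step brought in, leaving a single carbon. A drop of comparable order is therefore expected, though nothing yet shows whether a methyl stands where the fluorine-bearing ring of compound 1 stood. The expected step is a number 55 percentage points lower from compound 2 to compound 3 (beyond the scatter). Compound 3 is accordingly estimated at 45% in this assay, with a range from 20% to 75%.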

Compound 3, percent of the compound remaining: 80%
The estimate for compound 3 lay 35 percentage points below the measured number; measured number outside the range, above it.
By their numbers in this assay, from the lowest: compound 1; then compound 3; then compound 2.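

Replacing the large ring with methyl at this aromatic carbon, para to a large group, does not return the number to the level of compound 1: the change gives a number 20 percentage points lower from compound 2 to compound 3 (beyond the scatter), and the comparison with 4-fluorophenyl gives a number 33 percentage points higher from compound 1 to compound 3 (beyond the scatter). In this assay the low number therefore goes with 4-fluorophenyl specifically, not with the absence of the ring carrying the hetero atom, and the order of the three groups does not follow their size, since methyl, the smallest, lies between the two larger groups. No measurement in hand accounts for this order.

On these data alone, whether the fluorine or the carbon-only ring goes with the low number of compound 1 stays open, as does where a plain phenyl, a morpholine or a carboxylic acid would fall at this aromatic carbon. All three compounds share the rest of the structure, so the contribution of the shared core to these numbers, and whether the same order holds on a different core, cannot be read from them.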